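Swapping a Branched Chain for a Cyclopentylmethyl Group

The source may report more compounds than this note shows. Statements on the series, on what has been measured and on what is new or still open speak of the compounds shown alone.

Compounds that share one core can be compared by changing a single group and seeing how much of each compound cells tolerate. Here the changes fall on a nitrogen on an aromatic ring, and the read-out comes from an ADME assay on A549 cells (Homo sapiens) for cytotoxicity, read by resazurin assay, with a stated time of 48 h; a lower number here means that less compound is tolerated, a higher number that more compound is tolerated. Compound 1 `CC(=O)Nc1ccc(NC(=O)c2cc(Cl)ccc2O)c(Cl)c1` gives "not determined" (no result reported), so it adds no number to the comparison. Compound 2 `CCCNc1ccc(NC(=O)c2cc(Cl)ccc2O)c(Cl)c1`, which carries propyl, gives 22500 nM. Compound 3 `CCCCCCC(C)Nc1ccc(NC(=O)c2cc(Cl)ccc2O)c(Cl)c1`, which carries 1-methylheptyl, gives 23500 nM. Only these two numbers exist, and compound 3 stands level with compound 2, since a 1.0-fold higher number from compound 2 to compound 3 (0.02 log units; within the scatter) is no larger than the differences seen between repeated measurements.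

Compound 4 `O=C(Nc1ccc(NCC2CCCC2)cc1Cl)c1cc(Cl)ccc1O` has cyclopentylmethyl in place of 1-methylheptyl on a nitrogen on an aromatic ring. Going by the values given here, the one measured step that bears on this change is a 1.0-fold higher number from compound 2 to compound 3 (0.02 log units; within the scatter), where exchanging one group at this place left the number within the scatter. Among the compounds with values here, no measured compound carries a ring in this group, so the evidence is thin. No step beyond the scatter is therefore expected in this assay. The expected step is a 1.1-fold lower number from compound 3 to compound 4 (0.03 log units; within the scatter). For compound 4 the estimated value is 22000 nM, with an expected range of 11000 nM to 45000 nM.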

Compound 4, half-maximal cytotoxic concentration: 21500 nM
For compound 4 the middle estimate is 1.0-fold (0.01 log units) above the measured one; the measured number falls inside the stated range.
By their numbers in this assay, from the lowest: compounds 4, 2 and 3 (each within the scatter of the next).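

Going by these compounds alone, compound 4 is the first compound here with a ring on this nitrogen: cyclopentylmethyl, with one five-membered non-aromatic ring of carbon only, takes the place of the open 1-methylheptyl chain, and in this assay this gives a 1.1-fold lower number from compound 3 to compound 4 (0.04 log units; within the scatter). The comparison with the shorter propyl chain reads the same way, with a 1.0-fold lower number from compound 2 to compound 4 (0.02 log units; within the scatter), so in this assay a ring-bearing group, a straight chain and a branched chain all stand level at this place, and closing part of the chain into a ring makes no difference that can be told from the scatter. No measurement shown gives a reason for this levelness, so it remains an observation about these three compounds only.

As far as these compounds go, all three groups with numbers are made of carbon only, so it remains open whether a group carrying a carboxylic acid, a second amine or a hydroxyl would stand level with them at this nitrogen. The compounds shown also leave open what a phenyl ring or a group as small as methyl would do here.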